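The source may hold more compounds than are shown below. What is called first, only, known or untested is meant among the compounds shown, and "the series" means these compounds.

Of the compounds shown here, three built on the same core have been tested in a functional assay on PC43-10 cells (Cricetulus griseus) for inhibition, read by CellTiter-Blue, with a stated time of 96 h; on this read-out lower numbers stand for stronger inhibition and higher numbers for weaker inhibition: compound 1 (`Nc1nc2[nH]c(CCCCCC(=O)N[C@@H](CCC(=O)O)C(=O)O)cc2c(=O)[nH]1`), compound 2 (`Nc1nc2[nH]c(CCCCCCC(=O)N[C@@H](CCC(=O)O)C(=O)O)cc2c(=O)[nH]1`) and compound 3 (`Nc1nc2[nH]c(CCCCCC(=O)O)cc2c(=O)[nH]1`). Compound 1 gives > 1000 nM as a limit, not a number. Compound 2 gives > 1000 nM as a limit too. Compound 3 gives > 1000 nM as a limit as well. Compound 3 therefore stands with the other two at the limit of > 1000 nM in this assay, at which 3 of the 3 values shown sit, and has no exact number. Compound 4 (`Nc1nc2[nH]c(CCCCCCCC(=O)O)cc2c(=O)[nH]1`) differs from compound 3 in one place, counted as 2-carboxyethyl in place of carboxy on a saturated chain carbon, five bonds along the chain from an aromatic carbon in full: 2-carboxyethyl in place of carboxy on a saturated chain carbon, five bonds along the chain from an aromatic carbon. Going by the values given here, no measured pair shows the effect of this change, so no step beyond the scatter is expected in this assay for it. The expected step that the limit leaves unreadable from compound 3 to compound 4 is thus small and has no firm direction. Compound 4 is estimated at 1500 nM with an expected range from 500 nM to 5000 nM in this measurement.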

Compound 4, half-maximal inhibitory concentration: > 1000 nM
Compound 4: a limit, no number (the forecaster's own chance of this, stated with the estimate: 85%); the middle value does not contradict the limit.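

Going by these compounds alone, compound 3 and compound 4 each give only a limit, not a number, in this assay, so no step between them can be read: the limit of > 1000 nM in this assay, at which 4 of the 4 values shown sit. The compounds shown leave open how strongly any of them inhibits and whether changing the chain alters that.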